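From bromo to iodo on the shared core

A few compounds are considered here, and "the series" means these few. Any claim that something is new, unique, unknown or untested is made for them only; others in the source may bear on it.

compound 1 `Cc1ccc(NC(=O)/C=C/c2ccccc2)c(C(N)=O)c1`: 5500 nM
compound 2 `NC(=O)c1cc(Br)ccc1NC(=O)/C=C/c1ccccc1`: 5000 nM

In a functional assay on K562 cells (Homo sapiens) for inhibition, read by trypan blue exclusion, with a stated time of 48 h (a lower number here means a stronger inhibitor, a higher number a weaker inhibitor), compound 2 gives 5000 nM, level with compound 1 within the scatter of repeat measurements. Compound 3 `NC(=O)c1cc(I)ccc1NC(=O)/C=C/c1ccccc1` carries one change: iodo in place of bromo on an aromatic carbon. Going by the values given here, the one measured step at that carbon, with bromo in place of methyl, is a 1.1-fold lower number from compound 1 to compound 2 (0.04 log units; within the scatter), and it stays within the scatter. Among the compounds with values here, with only this step to go on, no change beyond the scatter, in either direction, is expected in this assay. The expected step is a 1.1-fold lower number from compound 2 to compound 3 (0.05 log units; within the scatter). Compound 3 is estimated at 4500 nM, with an expected range of 2000 nM to 10000 nM.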

Compound 3, half-maximal inhibitory concentration: 570 nM
The estimate for compound 3 lay 7.9-fold (0.90 log units) above the measured number; measured number outside the range, below it.
By their numbers in this assay, from the lowest: compound 3; then compounds 2 and 1 (each within the scatter of the next).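

Iodo in place of bromo gives an 8.8-fold lower number from compound 2 to compound 3 (0.94 log units; beyond the scatter) in this assay and iodo in place of methyl gives a 9.6-fold lower number from compound 1 to compound 3 (0.98 log units; beyond the scatter) on the same carbon. This carbon is therefore not indifferent to its group, which the level pair of methyl and bromo gave no sign of, and among these three groups iodo alone stands apart. Nothing measured here explains why.

Going by these compounds, whether other groups at this carbon, such as an amine, a carboxylic acid or a trifluoromethyl group, also lower the number stays open. So does whether chloro or fluoro would stand with bromo or with iodo.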